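A few compounds are considered here, and "the series" means these few. Any claim that something is new, unique, unknown or untested is made for them only; others in the source may bear on it.

Compound 1 `CCCc1nc(-c2ccccc2)c(CNCCN2CCN(c3cccc(C)c3)CC2)o1` gives 43.1% in an assay on HEK293 cells for inhibition of Voltage-dependent T-type calcium channel subunit alpha-1G (Homo sapiens), read by fluorescence, tested at 10 uM; a higher number here means more inhibition at the concentration tested (going by the name of the read-out), a lower number less inhibition.
Compound 2 `Cc1nc(-c2ccccc2)c(CNCCN2CCN(C(c3ccccc3)c3ccccc3)CC2)o1` gives 57.3% in this assay.
Compound 3 `CCCc1nc(-c2ccccc2)c(CNCCCN2CCN(c3cccc(F)c3)CC2)o1` gives 68.9% in this assay.

Across the three measured compounds, compound 1 stands at the lowest number. The nearest to it is compound 2, whose value sits higher by a gap that lies beyond the scatter, and the furthest is compound 3, higher still by a gap also beyond the scatter. Going by the values given here, no pair among the three differs in only one place, so none of these gaps can be read as the effect of a single change; they only show that the number in this assay is higher for compound 2 and compound 3 than for compound 1, across differences on the amine nitrogen in a ring and in the linker.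

The next compound, compound 4 `CCCc1nc(-c2ccccc2)c(CNCCN2CCN(c3ccc(C)cc3)CC2)o1`, is compound 1 with one change: 4-methylphenyl in place of 3-methylphenyl on an amine nitrogen in a ring. The two have the same atoms, joined differently. Among the compounds with values here, nothing measured so far isolates this kind of change, so no size can be read off for it. The expected step from compound 1 to compound 4 in this assay is a number 1.9 percentage points higher from compound 1 to compound 4 (within the scatter), which is no step beyond the scatter. Compound 4 is therefore estimated at 45%, with a range from 25% to 65%.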

Compound 4, a percentage reported as inhibition, at one concentration (the size of the read-out at that concentration, not a potency): 48.1%
Beside the measured number, compound 4's estimate is 3.1 percentage points below it; the measured number falls inside the stated range.
By their numbers in this assay, from the lowest: compounds 1, 4 and 2 (each within the scatter of the next, the first and the last beyond it); then compound 3.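

In this assay, going by these compounds alone, 4-methylphenyl in place of 3-methylphenyl on an amine nitrogen in a ring gives a number 5 percentage points higher from compound 1 to compound 4 (within the scatter) and this is the first comparison that isolates a single change. With the rest of compound 1 held fixed, this pair of isomers cannot be told apart in this read-out, so moving the methyl group around this phenyl ring has no effect here that can be separated from the scatter, on this one pair alone. Nothing at hand bears on the reason for this outcome.

Still open, going by these compounds, is whether a different group on this phenyl ring, such as a methoxy group or a chlorine atom, or a phenyl ring with no substituent, would shift the number beyond the scatter, and whether the same exchange of methylphenyl isomers would read alike with a longer chain in the linker. The separate contributions of the linker, the chain on the core and the group on the ring nitrogen cannot be read from compound 1, compound 2 and compound 3, which differ from one another in more than one place.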